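Aroylthiosemicarbazide series: chloro for methyl on the aroyl ring

The compounds below may be only part of what the source reports. "The series", "measured", "known", "first", "only" and "open" are said of these compounds alone.

Three compounds share the core and differ only in the aroyl part: compound 1 `O=C(NC(=S)NNc1ncnc2ccccc12)c1ccc(C(F)(F)F)cc1`, compound 2 `COc1cc2ncnc(NNC(=S)NC(=O)c3ccc(F)cc3)c2cc1OC` and compound 3 `Cc1ccc(C(=O)NC(=S)NNc2ncnc3ccccc23)cc1`. In a functional assay on CNE-2 cells (Homo sapiens) for cytotoxicity, read by MTT assay, with a stated time of 72 h (a lower number here means a stronger inhibitor, a higher number a weaker inhibitor), compound 1 gives 22500 nM, compound 2 gives 16100 nM and compound 3 gives 17200 nM. Compound 3 stands second highest of the three, but both gaps are within the scatter, so no ordering is claimed. Within the data shown here, the one single-place step is a 1.3-fold lower number from compound 1 to compound 3 (0.12 log units; within the scatter), which bears on the same ring. Compound 4 `O=C(NC(=S)NNc1ncnc2ccccc12)c1cccc(Cl)c1` carries 3-chlorophenyl in place of 4-methylphenyl on a carbonyl carbon. Among the measured compounds shown here, no measured step covers a chlorine at this position; the only step on this ring was within the scatter, so compound 4 is expected to show a 1.0-fold lower number from compound 3 to compound 4 (0.01 log units; within the scatter). The estimate for compound 4 is 17000 nM, range 8000 nM to 36000 nM.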

Compound 4, half-maximal inhibitory concentration: 2920 nM
The estimate for compound 4 lay 5.8-fold (0.77 log units) above the measured number; the measured number lies below the stated range.
By their numbers in this assay, from the lowest: compound 4; then compounds 2, 3 and 1 (each within the scatter of the next).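

In this assay, putting 3-chlorophenyl in place of 4-methylphenyl on the carbonyl carbon gives a 5.9-fold lower number from compound 3 to compound 4 (0.77 log units; beyond the scatter), so the aroyl part can move the number beyond the scatter, which a 1.3-fold lower number from compound 1 to compound 3 (0.12 log units; within the scatter) did not show. This pair changes both the group and where it sits on the ring, so the two effects cannot be separated. Nothing available explains the step.

On these data alone, whether the lower number belongs to the chlorine itself or to its place remains open. Also open, as far as these compounds go, is whether an amine or a carboxylic acid on the same phenyl ring would give a comparable number.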